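This account rests on a few compounds, and the source may have more. Where it says the series, first, only, none or still open, it means among the compounds named here.

Three compounds of the series carry numbers in a functional assay on RAW264.7 cells (Mus musculus) for inhibition, read by Griess assay, with stated times of 2 h and 24 h; a higher number here means a weaker inhibitor, a lower number a stronger inhibitor. Compound 1 `COc1ccc([C@@H]2CC(=O)c3c(O)cc(OCc4cn(C5CCCC5)nn4)cc3O2)cc1O` gives 10500 nM. Compound 2 `COc1ccc([C@@H]2CC(=O)c3c(O)cc(OCc4cn(Cc5ccccc5C(F)(F)F)nn4)cc3O2)cc1O` gives 12500 nM, and compound 3 `CCCn1cc(COc2cc(O)c3c(c2)O[C@H](c2ccc(OC)c(O)c2)CC3=O)nn1` gives 9670 nM. Compound 3 holds the lowest of the three numbers, yet the neighbours sit close: a 1.1-fold lower number from compound 1 to compound 3 (0.04 log units; within the scatter) and a 1.3-fold lower number from compound 2 to compound 3 (0.11 log units; within the scatter), both within the scatter, so no order among the three is claimed. Compound 4 `COc1ccc([C@@H]2CC(=O)c3c(O)cc(OCc4cn(Cc5ccccc5C#N)nn4)cc3O2)cc1O` differs from compound 3 by 2-cyanophenyl in place of ethyl on a saturated chain carbon bound to an aromatic nitrogen. The step that bears on this is the earlier swap on a saturated chain carbon bound to an aromatic nitrogen, a 1.3-fold lower number from compound 2 to compound 3 (0.11 log units; within the scatter), which stayed within the scatter; a 1.2-fold higher number from compound 1 to compound 2 (0.08 log units; within the scatter) likewise moved nothing beyond it. No step beyond the scatter in this assay is therefore expected for compound 4, a 1.1-fold higher number from compound 3 to compound 4 (0.06 log units; within the scatter). Compound 4 is estimated at 11000 nM, with a range of 5500 nM to 22000 nM.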

Compound 4, half-maximal inhibitory concentration: 14600 nM
Compound 4: middle estimate off by 1.3-fold (0.12 log units), on the low side; low and high end bracket the measured number.
By their numbers in this assay, from the lowest: compounds 3, 1, 2 and 4 (each within the scatter of the next).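

In this assay, 2-cyanophenyl in place of ethyl on a saturated chain carbon bound to an aromatic nitrogen gives a 1.5-fold higher number from compound 3 to compound 4 (0.18 log units; within the scatter), so bringing in an aromatic ring and a nitrile at this position stays within the scatter. Cyano in place of trifluoromethyl on an aromatic carbon gives a 1.2-fold higher number from compound 2 to compound 4 (0.07 log units; within the scatter), and exchanging the cyclopentyl group for 2-cyanobenzyl gives a 1.4-fold higher number from compound 1 to compound 4 (0.14 log units; within the scatter), so no step among these cyclopentyl, propyl and substituted benzyl groups leaves the scatter. No measurement at hand explains these numbers. Open, as far as these compounds go, is whether a primary amine or a carboxylic acid on this chain would move the number beyond the scatter.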